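Varying the Aromatic Amine on a Shared Core

The source may report more compounds than this note shows. Statements on the series, on what has been measured and on what is new or still open speak of the compounds shown alone.

Measured compounds:
Compound 1 `COc1cc(N(C)CCCO)ccc1/C=C1\C(=O)N(C2CCCCC2)C(=S)N1C` gives 990 nM in an assay on isolated protein for inhibition of NADPH oxidase 2 (Homo sapiens), read by chemiluminescence, in the presence of a further agent that is not named here; on this read-out higher numbers stand for weaker inhibition and lower numbers for stronger inhibition.
Compound 2 `CN1C(=S)N(C2CCCCC2)C(=O)/C1=C\c1ccc(N(C)C)cc1O` gives 2960 nM in this assay.
Compound 3 `CCN(CC)c1ccc(/C=C2\C(=O)N(C3CCCCC3)C(=S)N2C)c(O)c1` gives 1660 nM in this assay.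

Compound 3 holds the middle of the three numbers; compound 1 and compound 2 each lie within the scatter of it, so the three cannot be ranked. Compound 4 `CN1C(=S)N(C2CCCCC2)C(=O)/C1=C\c1ccc(N(C)CCCO)cc1O` is not yet measured. It differs from compound 3 in one place: (3-hydroxypropyl)(methyl)amino in place of diethylamino on an aromatic carbon.

Among the compounds with values here, one measured step bears on this change. The exchange of dimethylamino for diethylamino at the same aromatic carbon gave a 1.8-fold lower number from compound 2 to compound 3 (0.25 log units; within the scatter), a step within the scatter. Compound 1 already carries the entering (3-hydroxypropyl)(methyl)amino group, though with methoxy where compound 3 has hydroxy, and compound 1 gives 990 nM, close to the others. The amine variations seen so far have therefore moved this assay little, and compound 4 is expected to behave alike, with a step of a 1.1-fold lower number from compound 3 to compound 4 (0.04 log units; within the scatter) and no movement beyond the scatter. Compound 4 is estimated at 1500 nM, with a range from 600 nM to 3800 nM.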

Compound 4, half-maximal inhibitory concentration: 3390 nM
Compound 4: the middle estimate sits 2.3-fold (0.35 log units) below what was measured; the measured number falls inside the stated range.
By their numbers in this assay, from the lowest: compounds 1, 3, 2 and 4 (each within the scatter of the next, the first and the last beyond it).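

In this assay, (3-hydroxypropyl)(methyl)amino in place of diethylamino on this aromatic carbon gives a 2.0-fold higher number from compound 3 to compound 4 (0.31 log units; beyond the scatter), so a change of amine here can move the number beyond the scatter, which the earlier step of a 1.8-fold lower number from compound 2 to compound 3 (0.25 log units; within the scatter) had not shown. Set against dimethylamino, however, the same group gives a 1.1-fold higher number from compound 2 to compound 4 (0.06 log units; within the scatter), so 2-hydroxyethyl in place of hydrogen on the amine's chain shows no readable effect, and the order among the amines rests on compound 3 alone. With the amine held fixed, hydrogen in place of methyl on the oxygen gives a 3.4-fold higher number from compound 1 to compound 4 (0.53 log units; beyond the scatter), so the value of compound 1 cannot stand in for its hydroxy counterpart.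

Nothing available explains any of these steps. As far as these compounds go, it also stays open how a carboxylic acid or an amine in place of the hydroxy of the 3-hydroxypropyl chain, or a longer chain, would read in this assay.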